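The source may hold more compounds than are shown below. What is called first, only, known or untested is meant among the compounds shown, and "the series" means these compounds.

Of the compounds shown here, two have been measured in a physicochemical assay for lipophilicity; on this read-out lower numbers stand for lower lipophilicity and higher numbers for higher lipophilicity. Compound 1 `O=C(O)c1cncc(C2=C(c3cc(Cl)ccc3OCc3ccc(F)cc3F)CCC2)n1` gives 1.6 in this assay, the lower of the two numbers. Compound 2 `Cc1ncc(C2=C(c3cc(Cl)ccc3OCc3ccc(F)cc3)CCC2)cc1C(=O)O` gives 2.7 in this assay, a number that lies beyond the scatter above compound 1.

The step followed here leads from compound 1 to compound 3 `O=C(O)c1cnnc(C2=C(c3cc(Cl)ccc3OCc3ccc(F)cc3F)CCC2)c1`. The change is 5-carboxypyridazin-3-yl in place of 6-carboxypyrazin-2-yl on a double-bonded ring carbon; the two structures hold the same atoms, joined differently, so the rearrangement of the ring nitrogen atoms is the only difference.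

Because compound 1 gives 1.6 and compound 3 keeps every atom of it, no large movement in this assay is expected, and a step of about a number 0.30 log units lower from compound 1 to compound 3 (within the scatter) is estimated, small enough to be close to the scatter. Compound 3 is expected to come out at 1.3 in this assay, within a range from 0.8 to 1.8.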

Compound 3, distribution coefficient: 1.2
Compound 3: middle estimate off by 0.10 log units, on the high side, and the stated range covers the measured number.
By their numbers in this assay, from the lowest: compound 3; then compound 1; then compound 2.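

For the compounds shown here, until now no two compounds differed in one place only; here, in this assay, rearranging the ring nitrogen atoms while keeping every atom gives a step of a number 0.40 log units lower from compound 1 to compound 3 (beyond the scatter). At this place, on a double-bonded ring carbon, the two groups have the same counts of heavy atoms, hydrogen-bond donors and hydrogen-bond acceptors, yet the modest step lies beyond the usual scatter, so such counts alone do not settle the read-out for this pair. Nothing at hand bears on the reason for this shift.

From the compounds shown here alone, whether a step of this size would recur on a different core stays open. So does what happens on this same ring when an amide or a nitrile stands in place of the carboxylic acid.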